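This account rests on a few compounds, and the source may have more. Where it says the series, first, only, none or still open, it means among the compounds named here.

Of the compounds shown here, three have been tested in a functional assay on MDA-MB-231 cells (Homo sapiens) for inhibition, read by MTT assay, with a stated time of 72 h (a lower number here means a stronger inhibitor, a higher number a weaker inhibitor), and none of them has yet given a number. Compound 1 `COC(=O)c1ccc(-c2nnc(CCCOS(=O)(=O)c3ccc(C)cc3)[nH]2)cc1` reads > 100000 nM, which is a limit of the assay. Compound 2 `COC(=O)c1ccc(-c2cn(CCCC(=O)Nc3ccc(-c4ccccc4)cc3)nn2)cc1` reads > 100000 nM, also a limit. Compound 3 `COC(=O)c1ccc(-c2cn(CCCC(=S)Nc3ccc(C)cc3)nn2)cc1` reads > 100000 nM, again a limit and not a number. All three therefore sit at one mark, (the limit of > 100000 nM in this assay, at which 3 of the 3 values shown sit).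

Compound 4 `Cc1ccc(NC(=S)CCCn2cc(-c3ccc(C(F)(F)F)cc3)nn2)cc1` differs from compound 3 in one place, with trifluoromethyl in place of methoxycarbonyl on an aromatic carbon, para to a large group (trifluoromethyl in place of methoxycarbonyl on an aromatic carbon). No measured step between any two of these compounds shows what such a change can do. Starting from compound 3 at > 100000 nM, only a modest gain in this assay is expected, and the reading may well stay at the limit. The expected step is an at least 1.4-fold lower number from compound 3 to compound 4 (0.15 log units; that floor lies within the scatter). For compound 4 the estimated value is 70000 nM, with an expected range of 15000 nM to 200000 nM.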

Compound 4, half-maximal inhibitory concentration: 83200 nM
Beside the measured number, compound 4's estimate is 1.2-fold (0.08 log units) below it; low and high end bracket the measured number.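

In this assay compound 4 is the first compound shown to give a number rather than a limit, so this aromatic carbon, para to a large group, is a place where a change can bring the reading within the range of the assay. Trifluoromethyl in place of methoxycarbonyl gives an at least 1.2-fold lower number from compound 3 to compound 4 (0.07 log units; that floor lies within the scatter); this is only a floor, and the true size of the step cannot be read from it. The other compounds shown give no number to set beside it, and they all stay at one mark: the limit of > 100000 nM in this assay, at which 3 of the 4 values shown sit.

Going by these compounds, whether a nitrile or an amine on this same carbon would read differently remains open. So does whether a longer chain in place of the present one would change the reading of compound 4 in this assay.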